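The source may hold more compounds than are shown below. What is called first, only, known or untested is meant among the compounds shown, and "the series" means these compounds.

Among the measured compounds shown here, compound 3, `COc1ccc(/C=C/c2cc(OC)cc(OC)c2/C=C/C(=O)c2ccccc2C)cc1`, gives the lowest of the three numbers so far in a functional assay on HepG2 cells (Homo sapiens) for antiproliferative activity, read by MTT assay, with a stated time of 48 h (on this read-out lower numbers stand for stronger inhibition and higher numbers for weaker inhibition), with 5.3 ug/mL. Its nearest neighbour is compound 1, `COc1ccc(/C=C/c2cc(OC)cc(OC)c2/C=C/C(=O)c2ccc(N)cc2)cc1`, which in this assay gives 7.5 ug/mL; the step of a 1.4-fold lower number from compound 1 to compound 3 (0.15 log units; within the scatter) lies within the scatter. Furthest is compound 2, `COc1ccc(/C=C/c2cc(OC)cc(OC)c2/C=C/C(=O)c2cccc(Cl)c2)cc1`, which in this assay gives 9.5 ug/mL; the step of a 1.8-fold lower number from compound 2 to compound 3 (0.25 log units; within the scatter) also lies within the scatter. Since none of these steps is beyond the scatter, compound 3 cannot be called the most active of the three; the three numbers are in effect indistinguishable.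

Compound 4, `COc1ccc(/C=C/c2cc(OC)cc(OC)c2/C=C/C(=O)c2ccc(OC)cc2)cc1`, is the next compound of this series. It differs from compound 3 only on the carbonyl carbon: 4-methoxyphenyl in place of 2-methylphenyl on a carbonyl carbon.

Every step measured so far in this series concerns an exchange of the aryl group on that same carbonyl carbon: a 1.3-fold higher number from compound 1 to compound 2 (0.10 log units; within the scatter), a 1.4-fold lower number from compound 1 to compound 3 (0.15 log units; within the scatter) and a 1.8-fold lower number from compound 2 to compound 3 (0.25 log units; within the scatter). Each of these lies within the scatter, so three different aryl groups have left the read-out in this assay essentially unchanged. On that basis a fourth aryl group is expected to behave the same way, with no step beyond the scatter in either direction: a 1.3-fold higher number from compound 3 to compound 4 (0.11 log units; within the scatter). Compound 4 is therefore estimated at 6.8 ug/mL in this assay, within a range from 3.2 ug/mL to 14 ug/mL.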

Compound 4, half-maximal inhibitory concentration: 4.9 ug/mL
Beside the measured number, compound 4's estimate is 1.4-fold (0.14 log units) above it; the range from low to high includes it.
By their numbers in this assay, from the lowest: compounds 4, 3, 1 and 2 (each within the scatter of the next).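

Compound 4 puts a hydrogen-bond acceptor on the carbonyl carbon, which the 2-methylphenyl group of compound 3 lacks, yet in this assay this exchange gives only a 1.1-fold lower number from compound 3 to compound 4 (0.03 log units; within the scatter), so adding that acceptor to the aryl group does not shift the read-out measurably. Among the compounds shown here, the pair of compound 1 and compound 4 adds a cleaner comparison than the earlier steps, which also moved the substituent around the ring: here methoxy replaces amino on an aromatic carbon, and the result is a 1.5-fold lower number from compound 1 to compound 4 (0.18 log units; within the scatter). The pair furthest apart in the printed numbers also stays inside the usual variation, at a 1.9-fold lower number from compound 2 to compound 4 (0.29 log units; within the scatter), so no two of the four compounds can be told apart, and the data at hand offer no measurement that would explain this flat picture.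

The compounds shown leave open whether a group of another kind on the carbonyl carbon, such as a carboxylic acid on the ring, a longer alkoxy chain or a saturated cyclohexyl ring in place of the aryl group, would move the number beyond the scatter. They also leave open whether changes elsewhere on the shared core, for example to its methoxy groups, would matter more than any exchange at this carbonyl carbon.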